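This account rests on a few compounds, and the source may have more. Where it says the series, first, only, none or still open, it means among the compounds named here.

Of the compounds shown here, three built on one shared core have been tested in a functional assay on HCT-116 cells (Homo sapiens) for antiproliferative activity, read by MTT assay, with a stated time of 72 h; a higher number here means a weaker inhibitor, a lower number a stronger inhibitor. Compound 1 `Cc1ccc(C(=O)Nc2nc3ccc(NC(=O)CSc4ccc(Cl)cc4)cc3s2)cc1` gives 2120 nM, compound 2 `O=C(CSc1ccc(Cl)cc1)Nc1ccc2nc(NC(=O)c3ccc(C(F)(F)F)cc3)sc2c1` gives 930 nM, and compound 3 `O=C(CSc1cccc(O)c1)Nc1ccc2nc(NC(=O)c3ccc(C(F)(F)F)cc3)sc2c1` gives 510 nM. Compound 2 and compound 3 differ by 3-hydroxyphenyl in place of 4-chlorophenyl on a sulfur, and that change reads as a 1.8-fold lower number from compound 2 to compound 3 (0.26 log units; within the scatter). Compound 2 and compound 1 differ by methyl in place of trifluoromethyl on an aromatic carbon, a change that produced a 2.3-fold higher number from compound 2 to compound 1 (0.36 log units; beyond the scatter).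

Compound 4 `Cc1ccc(C(=O)Nc2nc3ccc(NC(=O)CSc4cccc(O)c4)cc3s2)cc1` has not yet been measured. It differs from compound 3 by methyl in place of trifluoromethyl on an aromatic carbon, the same change seen between compound 2 and compound 1, now made on the core of compound 3. Compound 4 is therefore expected to show a 2.4-fold higher number from compound 3 to compound 4 (0.37 log units; beyond the scatter), an expectation that rests on compound 1 having given a 2.3-fold higher number from compound 2 to compound 1 (0.36 log units; beyond the scatter). Compound 4 is estimated at 1200 nM, with a likely range from 550 nM to 2700 nM.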

Compound 4, half-maximal inhibitory concentration: 7730 nM
Beside the measured number, compound 4's estimate is 6.4-fold (0.81 log units) below it; the whole stated range lies below it.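

On the core of compound 3, methyl in place of trifluoromethyl gave a 15-fold higher number from compound 3 to compound 4 (1.18 log units; beyond the scatter) in this assay, so the direction of this change carried over from the earlier pair but its size did not: the same change on two cores in this assay, a 2.3-fold higher number (0.36 log units; beyond the scatter) from compound 2 to compound 1 and a 15-fold higher number (1.18 log units; beyond the scatter) from compound 3 to compound 4, 6.6-fold (0.82 log units) apart, beyond the scatter of two such steps. With methyl in place of trifluoromethyl, 3-hydroxyphenyl in place of 4-chlorophenyl gave a 3.6-fold higher number from compound 1 to compound 4 (0.56 log units; beyond the scatter), so that change did not carry over either: the same change on two cores in this assay, a 1.8-fold lower number (0.26 log units; within the scatter) from compound 2 to compound 3 and a 3.6-fold higher number (0.56 log units; beyond the scatter) from compound 1 to compound 4, 6.6-fold (0.82 log units) apart, beyond the scatter of two such steps. These two gaps are the same four compounds read in two ways, and they show that the two changes do not act independently, but not why, nor which step would be typical on other cores.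

The compounds shown leave open how the methyl and trifluoromethyl step behaves with an unsubstituted phenyl on the sulfur. They also leave open whether a nitrile or an amine in place of the trifluoromethyl would depend on the group at the sulfur in the same way.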